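A few compounds are considered here, and "the series" means these few. Any claim that something is new, unique, unknown or untested is made for them only; others in the source may bear on it.

Measured so far in this series:

Compound 1 `Cc1nc(S(C)(=O)=O)ccc1Oc1ncnc(OC2CCN(C(=O)OC(C)F)CC2)c1F`: 68%
Compound 2 `Cc1nc(S(C)(=O)=O)ccc1Oc1ncnc(OC2CCN(C(=O)O[C@H](C)CF)CC2)c1F`: 79%

Two compounds have been run in a functional assay on isolated protein for inhibition of Glucose-dependent insulinotropic receptor (Rattus norvegicus), read by HTRF and cAMP accumulation; a higher number here means a larger maximal response, a lower number a smaller maximal response. Going by the values given here, compound 2 holds the higher of the two numbers; its only neighbour is compound 1, and the single counted step, a number 11 percentage points higher from compound 1 to compound 2 (beyond the scatter), lies beyond the scatter.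

The next compound, compound 3 `Cc1nc(S(C)(=O)=O)ccc1Oc1ncnc(OC2CCN(C(=O)O[C@@H](C)CF)CC2)c1F`, awaits measurement in this assay. It has the same atoms and bonds as compound 2 and differs from it only in configuration as drawn: the two compounds have the same atoms and bonds and differ only in configuration as drawn: 1 of 1 stereo elements differ; a stereocentre at a saturated chain carbon is drawn R in compound 2 and S in compound 3.

Among the compounds with values here, no measured step bears on this change. Within the data shown here, the one step available, from compound 1 to compound 2, replaces one group by another and says nothing about an inversion at the stereocentre that is now in question. The direction of the step to compound 3 is therefore open, and a step in either direction, or none beyond the scatter, remains possible; the spread between the two measured numbers gives a rough sense of how far a single change in this part of the molecule has moved the readout.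

Compound 3 is expected to give 70%, within a range from 50% to 90%. The step this estimate implies is a number 9 percentage points lower from compound 2 to compound 3 (within the scatter).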

Compound 3, largest response reached (reported as efficacy), in percent of the reference or control that the assay uses: 84%
Beside the measured number, compound 3's estimate is 14 percentage points below it; the measured number falls inside the stated range.
By their numbers in this assay, from the lowest: compound 1; then compounds 2 and 3 (each within the scatter of the next).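

In this assay, inverting the stereocentre at the saturated chain carbon gives a number 5 percentage points higher from compound 2 to compound 3 (within the scatter), so this read-out does not separate the two drawn configurations of the 1-(fluoromethyl)ethyl group. Compounds 1 and 2 could not show this, and the comparison here is a clean one, with the configuration as the only variable: the fact that compounds 2 and 3 differ only in the configuration as drawn. The other new step, a number 16 percentage points higher from compound 1 to compound 3 (beyond the scatter), agrees in direction with a number 11 percentage points higher from compound 1 to compound 2 (beyond the scatter), so the rise seen with 1-(fluoromethyl)ethyl in place of 1-fluoroethyl on an oxygen next to a carbonyl group holds for both drawn configurations, and it does not depend on one configuration alone.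

The compounds shown leave open whether the fluorine itself contributes to the maximal response, a question that a plain isopropyl group on the same oxygen would address directly. They also leave open whether the lack of separation between configurations persists with a longer chain at this stereocentre, such as a 1-(fluoromethyl)propyl group, and whether the same holds on any read-out other than this assay.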